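Swapping a ring oxygen for sulfur on the thiocarbonyl

A few compounds are considered here, and "the series" means these few. Any claim that something is new, unique, unknown or untested is made for them only; others in the source may bear on it.

Compound 3 `Cc1cccc(/C(N)=N/NC(=S)N2CCOCC2)n1` gives 86.9% in a functional assay on HeLa cells (Homo sapiens) for cytotoxicity, read by MTT assay, with a stated time of 72 h, tested at 30 uM (on this read-out lower numbers stand for less inhibition of growth and higher numbers for more inhibition of growth at the one concentration tested), the highest of three numbers; compound 1 `N/C(=N\NC(=S)N1CCSCC1)c1ccccn1` gives 80.6%, within the scatter, while compound 2 `Cc1cccc(/C(N)=N/NC(=S)N2CCCC2)n1` gives 74.5%, beyond it. For the measured compounds named here, the one measured step, a number 12.4 percentage points higher from compound 2 to compound 3 (beyond the scatter), came with morpholin-4-yl in place of pyrrolidin-1-yl on a thiocarbonyl carbon. Compound 4 `Cc1cccc(/C(N)=N/NC(=S)N2CCSCC2)n1` is still unmeasured; it differs from compound 3 thus: thiomorpholin-4-yl in place of morpholin-4-yl on a thiocarbonyl carbon. Going by the values given here, no measured step exchanges morpholin-4-yl for thiomorpholin-4-yl, and compound 1 carries thiomorpholin-4-yl on a core without the methyl. The step from compound 3 to compound 4 is therefore expected to stay within the scatter, a number 4.9 percentage points lower from compound 3 to compound 4 (within the scatter). Compound 4 is estimated at 82%, between 70% and 92%.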

Compound 4, percent growth inhibition at one concentration: 85.3%
The estimate for compound 4 lay 3.3 percentage points below the measured number; the range from low to high includes it.
By their numbers in this assay, from the lowest: compounds 2, 1, 4 and 3 (each within the scatter of the next, the first and the last beyond it).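

On the thiocarbonyl carbon, exchanging the ring oxygen of morpholin-4-yl for sulfur leaves growth inhibition in this assay essentially unchanged, with a number 1.6 percentage points lower from compound 3 to compound 4 (within the scatter). Both six-membered rings stand apart from pyrrolidin-1-yl, with a number 10.8 percentage points higher from compound 2 to compound 4 (beyond the scatter), while the methyl on an aromatic carbon has no clear effect, with a number 4.7 percentage points higher from compound 1 to compound 4 (within the scatter). Nothing measured here explains these differences.

Going by these compounds, whether an open-chain dimethylamino group or a piperazine at this carbon would hold this level remains open. So does whether the core without the methyl would respond in the same way to morpholin-4-yl or pyrrolidin-1-yl.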